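This account rests on a few compounds, and the source may have more. Where it says the series, first, only, none or still open, it means among the compounds named here.

Compound 1 `C#CCSc1nc(Sc2ccccn2)c(C#N)c(-c2cc(OC)c(OC)c(OC)c2)n1` gives > 10000 nM as a limit
Compound 2 `C#CCSc1nc(Sc2nc[nH]n2)c(C#N)c(-c2cc(OC)c(OC)c(OC)c2)n1` gives > 20000 nM as a limit

Going by the values given here, in a functional assay on KYSE-70 cells for antiproliferative activity against KYSE-70 cell line (Homo sapiens), read by MTT assay, with a stated time of 72 h (on this read-out lower numbers stand for stronger inhibition and higher numbers for weaker inhibition), compound 2 has only a limit and no number, and the one other value is also a limit. The change to compound 3 `C#CCSc1nc(Sc2nc3ccccc3s2)c(C#N)c(-c2cc(OC)c(OC)c(OC)c2)n1` is 1,3-benzothiazol-2-yl in place of 1H-1,2,4-triazol-3-yl on a sulfur. Among the compounds with values here, the only measured step is a step that the two limits leave unreadable from compound 1 to compound 2 and it gives no size to carry over, though it also changes the group on that sulfur. No readable direction is therefore expected, and another limit is possible. The estimated step is an at least 1.3-fold lower number from compound 2 to compound 3 (0.12 log units; that floor lies within the scatter) and should be read with that caution. Compound 3 is estimated at 15000 nM within a range from 4000 nM to 40000 nM as expected here.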

Compound 3, half-maximal inhibitory concentration: > 20000 nM
Compound 3 gave a limit, no number; the forecaster's own chance of this, stated with the estimate: 60%; middle value at least 1.3-fold (0.12 log units) away from the limit.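

In this assay, going by these compounds alone, compound 3 gives > 20000 nM, a limit and not a number, so no step linking compound 1, compound 2 and compound 3 can be read. The compounds shown leave open whether these groups on a sulfur differ at all in antiproliferative activity.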